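Ester chain extension from compound 3 to compound 4

A few compounds are considered here, and "the series" means these few. Any claim that something is new, unique, unknown or untested is made for them only; others in the source may bear on it.

Measured in an assay on membranes from CHO cells for displacement of a labelled ligand from adenosine receptor A1 (Homo sapiens), read by scintillation counting, with a stated time of 60 min, tested at 1 uM; on this read-out higher numbers stand for more inhibition at the one concentration tested (going by the name of the read-out) and lower numbers for less inhibition:
compound 1 `CC1=C(C(=O)OCc2ccccc2)C(c2cccs2)NC(=O)N1` gives 45%
compound 2 `COC(=O)C1=C(C)NC(=S)NC1c1ccsc1` gives 3%
compound 3 `COC(=O)C1=C(C)N(C)C(=O)NC1c1ccco1` gives 45%

Compound 3 stands level with compound 1 at the digits read, and the two together make up the top of the three numbers. The gap between compound 3 and compound 2 is large and well beyond the usual scatter of this read-out. Compound 2 differs from compound 3 in more than one place, and nothing in that gap can be assigned to any single change.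

Compound 4 `CCCOC(=O)C1=C(C)N(C)C(=O)NC1c1ccco1` is the next entry and has not yet been measured in this assay. It differs from compound 3 in one place: ethyl in place of hydrogen on a saturated chain carbon bound to an oxygen next to a carbonyl group — methoxycarbonyl to propoxycarbonyl. Going by the values given here, no measured pair in the set differs by the ester chain alone, so this step has no direct precedent. Compound 1, which carries a different group on the oxygen next to the carbonyl, gives 45%, level with compound 3, though compound 1 also differs elsewhere. The expected step from compound 3 to compound 4 is no change at the digits printed from compound 3 to compound 4 (within the scatter), that is, none beyond the scatter. Compound 4 is accordingly estimated at 45%, with an expected range from 25% to 65%.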

Compound 4, a percentage reported as inhibition, at one concentration (the size of the read-out at that concentration, not a potency): 3%
The estimate for compound 4 lay 42 percentage points above the measured number; the whole stated range lies above it.
By their numbers in this assay, from the lowest: compounds 2 and 4 (each within the scatter of the next); then compounds 1 and 3 (each within the scatter of the next).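

In this assay, the ester chain proves to be a sensitive place: methoxycarbonyl to propoxycarbonyl, with ethyl in place of hydrogen on a saturated chain carbon bound to an oxygen next to a carbonyl group, gives a number 42 percentage points lower from compound 3 to compound 4 (beyond the scatter). Going by these compounds alone, this is the first step that can be read at a single place, as the rest of the structure is the same in both compounds. On the core of compound 3, this change alone is therefore enough to remove most of the inhibition seen at the one concentration tested, and nothing shown bears on why the step is so large.

Going by these compounds, it remains open whether an ethyl ester would keep the inhibition or already lose it, and whether an isopropyl ester, a carboxylic acid or an amide at this place would follow the propyl ester. A single pair also leaves open whether a step of this size would recur on a core carrying different groups elsewhere.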